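From 4-(trifluoromethyl)phenyl to 2-chlorophenyl on a shared core

The source may hold more compounds than are shown below. What is called first, only, known or untested is meant among the compounds shown, and "the series" means these compounds.

In a functional assay on K562 cells (Homo sapiens) for cytotoxicity, read by MTT assay, with a stated time of 72 h (on this read-out higher numbers stand for weaker inhibition and lower numbers for stronger inhibition), compound 1 `C=C1C(=O)[C@@]23C(=O)OC[C@]4(C(=O)CCC(C)(C)[C@H]4C=O)[C@@H]2CC[C@@H]1[C@H]3OC(C)=O` gives 1390 nM and compound 2 `C=C1C(=O)[C@@]23C(=O)OC[C@]4(C(=O)CCC(C)(C)[C@H]4C=O)[C@@H]2CC[C@@H]1[C@H]3OC(=O)c1ccc(C)cc1` gives 1270 nM. Compound 3 `C=C1C(=O)[C@@]23C(=O)OC[C@]4(C(=O)CCC(C)(C)[C@H]4C=O)[C@@H]2CC[C@@H]1[C@H]3OC(=O)c1ccc(C(F)(F)F)cc1` gives 2820 nM, the highest number of the three. Compound 4 `C=C1C(=O)[C@@]23C(=O)OC[C@]4(C(=O)CCC(C)(C)[C@H]4C=O)[C@@H]2CC[C@@H]1[C@H]3OC(=O)c1ccccc1Cl` has 2-chlorophenyl in place of 4-(trifluoromethyl)phenyl on a carbonyl carbon. Going by the values given here, three measured steps bear on this change. Exchanging the methyl for an aromatic group gave a 1.1-fold lower number from compound 1 to compound 2 (0.04 log units; within the scatter), but also a 2.0-fold higher number from compound 1 to compound 3 (0.31 log units; beyond the scatter), while the trifluoromethyl in place of methyl on the aromatic carbon gave a 2.2-fold higher number from compound 2 to compound 3 (0.35 log units; beyond the scatter). Among the compounds with values here, no chlorine-bearing compound has been measured, so compound 4 is expected to lie closer to compound 2 than compound 3 does. The expected step is a 1.7-fold lower number from compound 3 to compound 4 (0.22 log units; within the scatter). For compound 4 the estimate is 1700 nM, with an expected range of 850 nM to 3300 nM.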

Compound 4, half-maximal inhibitory concentration: 1220 nM
For compound 4 the middle estimate is 1.4-fold (0.14 log units) above the measured one; the range from low to high includes it.
By their numbers in this assay, from the lowest: compounds 4, 2 and 1 (each within the scatter of the next); then compound 3.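

In this assay, 2-chlorophenyl on the carbonyl carbon does not share the higher number of 4-(trifluoromethyl)phenyl, with a 2.3-fold lower number from compound 3 to compound 4 (0.36 log units; beyond the scatter), so an aromatic group here does not by itself bring that number. The remaining steps stay within the scatter, with a 1.0-fold lower number from compound 2 to compound 4 (0.02 log units; within the scatter) and a 1.1-fold lower number from compound 1 to compound 4 (0.06 log units; within the scatter), leaving compound 3 alone apart from the other three. Nothing available explains this difference. Still open, from the compounds shown here alone, is whether 4-chlorophenyl or 2-(trifluoromethyl)phenyl would follow compound 4 or compound 3, which would separate the group from where it sits on the ring. Going by these compounds, an aminophenyl or carboxyphenyl group at this carbonyl carbon also remains open.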